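This account rests on a few compounds, and the source may have more. Where it says the series, first, only, none or still open, it means among the compounds named here.

Compound 1 `C=CCNC(=C\C(=O)/C=C/c1ccc(O)c(OC)c1)/C=C/c1ccc(O)c(OC)c1`. In an ADME assay on Caco-2 cells (Homo sapiens) for inhibition, read by sulforhodamine B assay, with a stated time of 72 h (on this read-out lower numbers stand for stronger inhibition and higher numbers for weaker inhibition), compound 1 gives > 25000 nM, a limit of the assay.
Compound 2 `COc1cc(/C=C/C(=O)/C=C(/C=C/c2ccc(OC(C)=O)c(OC)c2)NC2CCCCC2)ccc1OC(C)=O`. In this assay compound 2 gives > 25000 nM, a limit of the assay.
Compound 3 `O=C(/C=C(/C=C/c1ccc(O)cc1)NC1CCCCC1)/C=C/c1ccc(O)cc1`. In this assay compound 3 gives > 25000 nM, a limit of the assay.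

Compound 1 stands with the others at the limit, since (the limit of > 25000 nM in this assay, at which 3 of the 3 values shown sit); no number separates it from compound 2 or compound 3, and no ordering among them can be read from limits.

Compound 4 `COc1cc(/C=C/C(=O)/C=C(/C=C/c2ccc(O)c(OC)c2)NCC(C)C)ccc1O` differs from compound 1 as follows: isopropyl in place of vinyl on a saturated chain carbon bound to an amine nitrogen

Among the compounds with values here, no measured pair in this assay differs at this place, so no step size is known. From compound 1 to compound 4 no step beyond the scatter is expected, a step that the limit leaves unreadable from compound 1 to compound 4. Compound 4 is therefore expected to sit at 30000 nM, with a range from 15000 nM to 100000 nM, most likely reported again as a limit.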

Compound 4, half-maximal inhibitory concentration: > 25000 nM
Compound 4 gave a limit, no number; the forecaster's own chance of this, stated with the estimate: 85%; the middle value is on the limit's open side.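

Compound 1 and compound 4 both stand at a limit, so no step from allyl to isobutyl can be read between them: the limit of > 25000 nM in this assay, at which 4 of the 4 values shown sit.

The compounds shown leave open whether any change to the shared core would give a readable number in this assay.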